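A Single Fluorine on the Shared Core

The source may hold more compounds than are shown below. What is called first, only, known or untested is meant among the compounds shown, and "the series" means these compounds.

Measured so far:
compound 1 `Oc1ccccc1CNc1ccc(-c2ccccc2)cc1` — 1820 nM
compound 2 `N#Cc1ccc(-c2ccc(NCc3ccccc3O)cc2)cc1` — "not active" (no number reported)

Within the data shown here, in a functional assay on Jurkat cells (Homo sapiens) for activation, with a stated time of 24 h (on this read-out higher numbers stand for an effect only at larger amounts of compound and lower numbers for an effect already at smaller amounts), compound 1 gives 1820 nM and is the only compound with a number. Compound 2 is reported in this assay as "not active" (no number reported) and yields no number. Compound 3 `Oc1ccccc1CNc1ccc(-c2ccccc2)c(F)c1` differs from compound 1 by fluoro in place of hydrogen on an aromatic carbon. Among the measured compounds shown here, no measured pair shows a change of this kind, so the expected step of a 1.2-fold lower number from compound 1 to compound 3 (0.08 log units; within the scatter) is put at no size beyond the usual scatter. Compound 3 is therefore estimated at 1500 nM, expected to fall between 600 nM and 4000 nM.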

Compound 3, half-maximal effective concentration: 2850 nM
For compound 3 the middle estimate is 1.9-fold (0.28 log units) below the measured one, within the range that was stated.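

In this assay, placing fluoro in place of hydrogen on this aromatic carbon, ortho to a phenyl group, gives a 1.6-fold higher number from compound 1 to compound 3 (0.19 log units; within the scatter) and leaves a measurable effect in place. This carbon of the shared core therefore accepts a fluoro group without a change that can be told apart from compound 1. Nothing available here offers an explanation for this result. Going by these compounds, whether chlorine, a methoxy group or an amine on this same carbon would shift the number beyond the scatter stays open. Also open, on these data alone, is whether fluoro on another aromatic carbon of the shared core would behave the same way.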